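Fluorine Added to a Weakly Cytotoxic Phenyltriazole

This account rests on a few compounds, and the source may have more. Where it says the series, first, only, none or still open, it means among the compounds named here.

Compound 2 `O=C1C[C@H](OCc2cn(-c3ccccc3)nn2)[C@H]2CO[C@@H]1O2` is one of two measured compounds that share the same core. In a functional assay on MDA-MB-231 cells (Homo sapiens) for cytotoxicity, read by MTT assay, with a stated time of 48 h (a lower number here means a stronger inhibitor, a higher number a weaker inhibitor), compound 2 gives 25200 nM, and this is the only number shown. Compound 1 `CCCCCCCCn1cc(CO[C@H]2CC(=O)[C@@H]3OC[C@H]2O3)nn1`, which carries octyl on the aromatic nitrogen, gives in this assay > 50000 nM, a limit of the assay and not a number (the limit of > 50000 nM in this assay, at which 1 of the 2 values shown sits). The step of an at least 1.9-fold lower number from compound 1 to compound 2 (0.29 log units; that floor lies within the scatter) therefore has a floor that lies within the scatter. Compound 3 `O=C1C[C@H](OCc2cn(-c3ccc(F)cc3)nn2)[C@H]2CO[C@@H]1O2` differs from compound 2 by fluoro in place of hydrogen on an aromatic carbon. Among the compounds with values here, no measured step changes a substituent on the phenyl ring, so only the step from compound 1 to compound 2 offers any guide, and it shows at most a small change. Compound 3 is therefore expected to sit near compound 2, with a step of a 1.3-fold lower number from compound 2 to compound 3 (0.10 log units; within the scatter) not beyond the scatter. The estimate for compound 3 in this assay is 20000 nM, between 8000 nM and 50000 nM.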

Compound 3, half-maximal inhibitory concentration: 23700 nM
For compound 3 the middle estimate is 1.2-fold (0.07 log units) below the measured one; low and high end bracket the measured number.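

Fluoro in place of hydrogen is the first change shown on the phenyl ring itself, and in this assay it gives a 1.1-fold lower number from compound 2 to compound 3 (0.03 log units; within the scatter), so this position, para to a large group, takes a fluorine with no change that can be told from the scatter. Exchanging octyl for 4-fluorophenyl on the aromatic nitrogen gives an at least 2.1-fold lower number from compound 1 to compound 3 (0.32 log units; beyond the scatter), the first step from the octyl compound whose floor lies beyond the scatter, though only modestly. The value of compound 1 on which that floor rests is a limit and not a number: the limit of > 50000 nM in this assay, at which 1 of the 3 values shown sits.

Going by these compounds, whether an amine, a carboxylic acid or a methoxy group at this position would shift the number beyond the scatter stays open. So does the effect of a chain shorter than octyl on the aromatic nitrogen.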